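The source may report more compounds than this note shows. Statements on the series, on what has been measured and on what is new or still open speak of the compounds shown alone.

Compounds measured in an ADME assay on WI-38 cells (Homo sapiens) for cytotoxicity, read by MTT assay, with a stated time of 72 h; a lower number here means a stronger inhibitor, a higher number a weaker inhibitor:
- compound 1 `CN(C)CCn1cnnc1-c1cc(Oc2ccc(NC(=O)N/N=C/c3c[nH]c4ccccc34)cc2F)ccn1`: 3620 nM
- compound 2 `CN(C)CCn1cnnc1-c1cc(Oc2ccc(NC(=O)N/N=C/c3ccc(Cl)cc3)cc2F)ccn1`: 1870 nM
- compound 3 `CN(C)CCn1cnnc1-c1cc(Oc2ccc(NC(=O)N/N=C/c3ccc(O)cc3)cc2F)ccn1`: "not determined" (no result reported)

Compound 3 stands without a number in this assay. Among the measured compounds shown here, the two compounds that do carry a number are compound 1 and compound 2; the step of a 1.9-fold lower number from compound 1 to compound 2 (0.29 log units; within the scatter) is the only measured step and it lies within the scatter. For the measured compounds named here, it concerns a change of the aromatic group on the carbon with a double bond to nitrogen, but neither of its groups is the one that changes here.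

Compound 4 `Cc1cc(/C=N/NC(=O)Nc2ccc(Oc3ccnc(-c4nncn4CCN(C)C)c3)c(F)c2)cc(C)c1O` differs from compound 3 by 4-hydroxy-3,5-dimethylphenyl in place of 4-hydroxyphenyl on a carbon with a double bond to nitrogen. Going by the values given here, no measured step bears on this change: the step from compound 1 to compound 2 exchanges a different pair of groups at that carbon, and compound 3 itself has no value to anchor the step. What the data give is the range spanned by compound 1 and compound 2, which are within the scatter of each other in this assay, and the fact that both changes seen and proposed sit on the same carbon with a double bond to nitrogen.

Among the compounds with values here, on that basis no step beyond the scatter is expected for compound 4 in this assay relative to the two numbers known for the series. Compound 4 is estimated at 2600 nM, with a range from 800 nM to 9000 nM, the width reflecting that compound 3 has no number of its own.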

Compound 4, half-maximal inhibitory concentration: 3610 nM
Beside the measured number, compound 4's estimate is 1.4-fold (0.14 log units) below it, and the stated range covers the measured number.
By their numbers in this assay, from the lowest: compounds 2, 4 and 1 (each within the scatter of the next).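

In this assay, the carbon with a double bond to nitrogen now has a third aromatic group with a number, the 4-hydroxy-3,5-dimethylphenyl of compound 4, and the new readings are (a 1.9-fold higher number from compound 2 to compound 4 (0.29 log units; within the scatter)) and (a 1.0-fold lower number from compound 1 to compound 4 (0.00 log units; within the scatter)). Together with the earlier step, this places 4-chlorophenyl, 1H-indol-3-yl and 4-hydroxy-3,5-dimethylphenyl within the scatter of one another in every listed comparison, so the change of group at this carbon has not yet separated any of the three, even though one is a two-ring group and the others carry different substituents on a single ring. No measurement is available to explain this absence of separation.

From the compounds shown here alone, the step from compound 3 to compound 4 cannot be read, so the contribution of the two methyl groups added to 4-hydroxyphenyl remains unknown. Going by these compounds, it also remains open whether an amine, a carboxylic acid or a cyclohexyl group on this carbon would give a number beyond the scatter of this narrow set.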